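The source may report more compounds than this note shows. Statements on the series, on what has been measured and on what is new or still open speak of the compounds shown alone.

In a physicochemical assay for solubility, in phosphate buffer, with a stated time of 18 h (a lower number here means a less soluble compound, a higher number a more soluble compound), two compounds have been measured so far. Compound 1 `Cc1c[nH]c(-c2nc(C(C)(C)C)nc3nc(N)c(C#N)c(N)c23)n1` gives 5000 nM, and compound 2 `CC(C)(C)c1nc(-c2ncn[nH]2)c2c(N)c(C#N)c(N)nc2n1` gives 64500 nM, the higher of the two numbers. Within the data shown here, the only measured step is a 13-fold higher number from compound 1 to compound 2 (1.11 log units; beyond the scatter), a large one, beyond the scatter, with 1H-1,2,4-triazol-5-yl in place of 4-methyl-1H-imidazol-2-yl on an aromatic carbon.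

Compound 3 `CC(C)(C)c1nc(-c2ncco2)c2c(N)c(C#N)c(N)nc2n1` keeps the shared core and changes the same place, with 1,3-oxazol-2-yl in place of 1H-1,2,4-triazol-5-yl on an aromatic carbon. The measured step bears on this change only indirectly. Among the measured compounds shown here, it shows that a swap of one ring at this place can move the number a long way, but no compound with 1,3-oxazol-2-yl has been measured. Compound 2 holds the top number at 64500 nM, so a fall is taken as the likelier direction, though the size remains uncertain. The expected change is a 3.2-fold lower number from compound 2 to compound 3 (0.51 log units; beyond the scatter), a moderate step that may not clear the scatter by much. For compound 3 the estimated value is 20000 nM, with an expected range from 5000 nM to 70000 nM.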

Compound 3, solubility: 50000 nM
Compound 3: the middle estimate sits 2.5-fold (0.40 log units) below what was measured; low and high end bracket the measured number.
By their numbers in this assay, from the lowest: compound 1; then compounds 3 and 2 (each within the scatter of the next).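

In this assay, the exchange at this place on the shared core reads a 1.3-fold lower number from compound 2 to compound 3 (0.11 log units; within the scatter), so going from 1H-1,2,4-triazol-5-yl to 1,3-oxazol-2-yl, with 1 hydrogen-bond donor in the leaving group and 0 hydrogen-bond donors in the entering one, does not separate these two compounds. The other new step, a 10-fold higher number from compound 1 to compound 3 (1.00 log units; beyond the scatter), lies beyond the scatter, so the wide gap from compound 1 is no longer tied to 1H-1,2,4-triazol-5-yl alone and now appears with a second five-membered aromatic ring. Nothing given here accounts for either step, and the numbers alone offer no explanation.

As far as these compounds go, whether the low number of compound 1 goes with the methyl group or with the imidazole ring itself stays open, and a compound carrying unsubstituted 1H-imidazol-2-yl at this place would be needed to tell these apart. Also open, from the compounds shown here alone, is how the number responds to a group without a ring at this place, such as an amine or a carboxylic acid, or to a replacement of the tert-butyl group elsewhere on the core.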